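Working notes: from compound 3 to compound 4

The source may hold more compounds than are shown below. What is called first, only, known or untested is meant among the compounds shown, and "the series" means these compounds.

Measured in a functional assay on A549 cells (Homo sapiens) for antiproliferative activity, read by MTT assay, with a stated time of 72 h (a lower number here means a stronger inhibitor, a higher number a weaker inhibitor), as follows:
compound 1 `CCC/C=C/C(=O)Nc1cccc(Oc2nc(Nc3cccc(OC)c3)nc3c2CSCC3)c1` gives 11800 nM
compound 2 `C=CC(=O)Nc1cccc(Oc2nc(Nc3ccc(OC)cc3)nc3c2CSCC3)c1` gives 4220 nM
compound 3 `C/C=C/C(=O)Nc1cccc(Oc2nc(Nc3ccc(OC)cc3)nc3c2CSCC3)c1` gives 22200 nM

In this assay compound 3 lies within the scatter of compound 1 and clearly apart from compound 2, which has the lowest number of the three. The next compound is compound 4 `CCC/C=C/C(=O)Nc1cccc(Oc2nc(Nc3ccc(OC)cc3)nc3c2CSCC3)c1`, and the change from compound 3 is ethyl in place of hydrogen on a saturated chain carbon bound to a double-bonded chain carbon on the group carried by the carbonyl, so that prop-1-en-1-yl becomes pent-1-en-1-yl.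

Among the compounds with values here, only one measured step bears on this change: a 5.3-fold higher number from compound 2 to compound 3 (0.72 log units; beyond the scatter) for prop-1-en-1-yl in place of vinyl on a carbonyl carbon. It concerns the same group and points to a higher number as that group grows. It is, however, a single observation of a different change, and nothing measured shows whether the direction would continue. Its size is therefore not carried over, and no shift beyond the scatter is expected in this assay for this step. The expected change is a 1.2-fold lower number from compound 3 to compound 4 (0.09 log units; within the scatter) in this estimate. The estimated value for compound 4 is 18000 nM with an expected range from 8000 nM to 40000 nM in this assay.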

Compound 4, half-maximal inhibitory concentration: 11900 nM
For compound 4 the middle estimate is 1.5-fold (0.18 log units) above the measured one; the range from low to high includes it.
By their numbers in this assay, from the lowest: compound 2; then compounds 1, 4 and 3 (each within the scatter of the next).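

In this assay, ethyl in place of hydrogen on a saturated chain carbon bound to a double-bonded chain carbon gives a 1.9-fold lower number from compound 3 to compound 4 (0.27 log units; within the scatter) and so does not separate pent-1-en-1-yl from prop-1-en-1-yl. Vinyl on the carbonyl stays apart from both groups, with a 5.3-fold higher number from compound 2 to compound 3 (0.72 log units; beyond the scatter) alongside a 2.8-fold higher number from compound 2 to compound 4 (0.45 log units; beyond the scatter) in the same assay, so among compounds 2, 3 and 4 the only separation lies between vinyl and the two longer groups, not between those two. Within the data shown here, the first reading at the other varied place, 4-methoxyphenyl in place of 3-methoxyphenyl on a nitrogen on an aromatic ring, gives a 1.0-fold higher number from compound 1 to compound 4 (0.00 log units; within the scatter) with pent-1-en-1-yl on the carbonyl, so no separation appears there either.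

Nothing available gives a cause for any of these steps. On these data alone, it remains open whether a longer chain on the double bond, or an amine at its end, would stay with compound 3 and compound 4 or come closer to compound 2, and whether the methoxy shift would read the same with vinyl on the carbonyl.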